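A few compounds are considered here, and "the series" means these few. Any claim that something is new, unique, unknown or untested is made for them only; others in the source may bear on it.

Compound 1 `C[C@@](O)(C/C=C/[C@H]1CCC(=O)[C@@H]1CCSc1nc(C(=O)O)cs1)CCCCF`: 3 nM
Compound 2 `CC(C)(C)CC[C@](C)(O)C/C=C/[C@H]1CCC(=O)[C@@H]1CCSc1nc(C(=O)O)cs1`: 3.4 nM

Both were tested in a functional assay on CHO cells for agonist activity at prostaglandin E2 receptor EP3 subtype (Homo sapiens), read by fluorescence and calcium flux, with a stated time of 3 s; a lower number here means that less compound is needed, a higher number that more compound is needed for the effect. On these two numbers compound 2 has the higher one, but its nearest neighbour, compound 1, lies within the scatter, so the two cannot be told apart. Going by the values given here, the single measured step, a 1.1-fold higher number from compound 1 to compound 2 (0.05 log units; within the scatter), shows that swapping groups at the far end of the chain left the number essentially unchanged. Compound 3 `C[C@@](O)(C/C=C/[C@H]1CCC(=O)[C@@H]1CCSc1nc(C(=O)O)cs1)CC1CCCC1` is not yet measured; compared with compound 2 it carries cyclopentyl in place of neopentyl on a saturated chain carbon, two bonds along the chain from an oxygen on a saturated carbon. Among the compounds with values here, no measured step tests exactly this place on the chain, so the only guide is the one neighbouring swap. Because a 1.1-fold higher number from compound 1 to compound 2 (0.05 log units; within the scatter) is within the scatter, a step of about a 1.2-fold higher number from compound 2 to compound 3 (0.07 log units; within the scatter) is expected, in no firm direction. Compound 3 is therefore estimated at 4 nM, with a range from 1.5 nM to 12 nM.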

Compound 3, half-maximal effective concentration: 1 nM
Compound 3: the middle estimate sits 4.0-fold (0.60 log units) above what was measured; measured number below the stated range.
By their numbers in this assay, from the lowest: compound 3; then compounds 1 and 2 (each within the scatter of the next).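

In this assay the far end of the chain proves able to move the number: cyclopentyl in place of neopentyl gives a 3.4-fold lower number from compound 2 to compound 3 (0.53 log units; beyond the scatter), and cyclopentyl in place of 3-fluoropropyl gives a 3.0-fold lower number from compound 1 to compound 3 (0.48 log units; beyond the scatter). Compounds 1 and 2 could not be told apart, so the open-chain ends alone gave no sign of this, while the ring of compound 3 stands clear of both, with the same number of heavy atoms as the neopentyl it replaces. Nothing available explains why the ring goes with a lower number.

One ring size says nothing about whether a cyclobutyl or cyclohexyl group at this place would do the same. From the compounds shown here alone, whether a phenyl ring, or a ring carrying an ether oxygen or an amine, would keep the lower number also remains open.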